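The source may hold more compounds than are shown below. What is called first, only, known or untested is meant among the compounds shown, and "the series" means these compounds.

Of the compounds shown here, three built on a shared core have been measured in a functional assay on HepG2 cells (Homo sapiens) for cytotoxicity, read by sulforhodamine B assay, with a stated time of 48 h; a lower number here means a stronger inhibitor, a higher number a weaker inhibitor. Compound 1 `C/C(=N\n1c(N)cc(N)c(C#N)c1=O)c1ccc(NS(=O)(=O)c2ccc(C)cc2)cc1` gives 37000 nM in this assay. Compound 3 `C/C(=N/NC(=O)/C(C#N)=C/N(C)C)c1ccc(NS(=O)(=O)c2ccc(C)cc2)cc1` gives 37800 nM in this assay. Compound 2 `Cc1ccc(S(=O)(=O)Nc2ccc(-c3cc(-c4ccc([N+](=O)[O-])cc4)[nH]n3)cc2)cc1` gives 44800 nM in this assay, the highest of the three numbers, though its separation from compound 3 and from compound 1 lies within the scatter, so no order among the three can be read from these values. Compound 4 `Cc1ccc(S(=O)(=O)Nc2ccc(-c3cc(-c4ccc([N+](=O)[O-])cc4)n(C(N)=S)n3)cc2)cc1` has not yet been measured. It differs from compound 2 in a single place: a group of 3 heavy atoms (1 carbon, 1 nitrogen, 1 sulfur; no ring) in place of a hydrogen atom, on an aromatic nitrogen The group that enters sits on an aromatic nitrogen. Among the compounds with values here, no pair of measured compounds differs in only one place, so there is no measured step to lean on. The three measured values cluster closely, and compound 4 is expected to stay near them, with an estimated step of a 1.4-fold lower number from compound 2 to compound 4 (0.15 log units; within the scatter) that is not expected to go beyond the scatter. Compound 4 is expected to give 32000 nM in this assay, within an estimated range from 10000 nM to 90000 nM.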

Compound 4, half-maximal inhibitory concentration: "not active" (no number reported)
Nothing numeric was reported for compound 4, and the estimate cannot be compared.
By their numbers in this assay, from the lowest: compounds 1, 3 and 2 (each within the scatter of the next).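

Within the data shown here, compound 4 is reported as not active in this assay with no number, so no step from compound 2 to compound 4 can be read. The compounds shown leave open how the group on the aromatic nitrogen relates to this result, and no evidence bears on it.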